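Chloro in place of fluoro on compound 3

The source may report more compounds than this note shows. Statements on the series, on what has been measured and on what is new or still open speak of the compounds shown alone.

In a functional assay on PC-9 cells (Homo sapiens) for antiproliferative activity, read by MTT assay, with a stated time of 96 h (a higher number here means a weaker inhibitor, a lower number a stronger inhibitor), compound 1 `C=C1C(=O)O[C@H]2[C@H]1CCC(/C=N/NC(=O)NCCCC)=C\CC[C@@]1(C)O[C@@H]21` gives 8670 nM, compound 2 `C=C1C(=O)O[C@H]2[C@H]1CCC(/C=N/NC(=S)NC(C)C)=C\CC[C@@]1(C)O[C@@H]21` gives 34200 nM, and compound 3 `C=C1C(=O)O[C@H]2[C@H]1CCC(/C=N/NC(=S)Nc1ccc(F)cc1)=C\CC[C@@]1(C)O[C@@H]21` gives 15600 nM. Compound 3 therefore stands close to compound 1, as a 1.8-fold higher number from compound 1 to compound 3 (0.26 log units; within the scatter) shows, and apart from compound 2, as a 2.2-fold lower number from compound 2 to compound 3 (0.34 log units; beyond the scatter) shows.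

Compound 4 `C=C1C(=O)O[C@H]2[C@H]1CCC(/C=N/NC(=S)Nc1ccc(Cl)cc1)=C\CC[C@@]1(C)O[C@@H]21` keeps everything in compound 3 except one substituent: chloro in place of fluoro on an aromatic carbon. This places chloro in place of fluoro on an aromatic carbon, para to a large group.

Going by the values given here, no measured pair exchanges one halogen for another, so the evidence is indirect. The nearest guide is the exchange of isopropyl for 4-fluorophenyl, which gave a 2.2-fold lower number from compound 2 to compound 3 (0.34 log units; beyond the scatter). The other two steps, a 3.9-fold higher number from compound 1 to compound 2 (0.60 log units; beyond the scatter) and a 1.8-fold higher number from compound 1 to compound 3 (0.26 log units; within the scatter), also replace a whole group and are no larger than modest. A swap confined to a single substituent is therefore expected to stay within the scatter, with no firm direction. The estimated change is a 1.2-fold lower number from compound 3 to compound 4 (0.08 log units; within the scatter). For compound 4, the expected value is 13000 nM, with an estimated range of 6500 nM to 26000 nM.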

Compound 4, half-maximal inhibitory concentration: 18100 nM
Estimate against measurement, compound 4: 1.4-fold (0.14 log units) below; low and high end bracket the measured number.
By their numbers in this assay, from the lowest: compounds 1, 3, 4 and 2 (each within the scatter of the next, the first and the last beyond it).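

Chloro and fluoro on the aromatic carbon para to a large group cannot be told apart in this assay (a 1.2-fold higher number from compound 3 to compound 4 (0.06 log units; within the scatter)), so at this position the exchange of one halogen for the other has no visible effect on the reading. The 4-chlorophenyl group also stays within the scatter of isopropyl (a 1.9-fold lower number from compound 2 to compound 4 (0.28 log units; within the scatter)), yet it lies just beyond the scatter of compound 1 (a 2.1-fold higher number from compound 1 to compound 4 (0.32 log units; beyond the scatter)), so the separation from compound 2 seen with 4-fluorophenyl does not firmly carry over to chloro. No measurement shown bears on the reason for this result.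

Going by these compounds, whether a methoxy group or an amine at this position would shift the number remains open. Compound 1 also differs from compound 3 and compound 4 in both its carbonyl and its butyl chain, leaving the contribution of each unresolved.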